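The source may report more compounds than this note shows. Statements on the series, on what has been measured and on what is new or still open speak of the compounds shown alone.

Compound 1 `Nc1ncnc2c1c(Oc1cc(C(F)(F)F)ccn1)nn2C1CC1`: > 2.41 h, a limit of the assay
Compound 2 `Nc1ncnc2c1c(Oc1cc(C(F)(F)F)ccn1)nn2[C@H]1C[C@H](F)C1`: 2.03 h

Among the measured compounds shown here, in an ADME assay on microsomes from liver (Homo sapiens) for metabolic stability, read by LC-MS, using NADPH, with a stated time of 10 min, tested at 10 uM (a lower number here means that the compound disappears faster, a higher number that the compound lasts longer), compound 2 gives the only exact number of the pair, 2.03 h. Compound 3 `Nc1ncnc2c1c(Oc1cc(C(F)(F)F)ccn1)nn2C1CCC(O)C1` carries 3-hydroxycyclopentyl in place of 3-fluorocyclobutyl on an aromatic nitrogen. For the measured compounds named here, the only measured step at this place, an at least 1.1-fold lower number from compound 1 to compound 2 (0.07 log units; that floor lies within the scatter), is a floor and offers a thin guide. The expected step is therefore a 1.2-fold lower number from compound 2 to compound 3 (0.08 log units; within the scatter). Compound 3 is estimated at 1.7 h, with an expected range of 0.7 h to 3.5 h.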

Compound 3, half-life: > 2.41 h
Compound 3 gave a limit, no number (the forecaster's own chance of this, stated with the estimate: 15%); middle value at least 1.4-fold (0.15 log units) from the limit.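

In this assay, 3-hydroxycyclopentyl in place of 3-fluorocyclobutyl gives an at least 1.1-fold higher number from compound 2 to compound 3 (0.07 log units; that floor lies within the scatter). The aromatic nitrogen can therefore carry a five-membered ring with a hydrogen-bond donor, and compound 3 still reaches a limit of the assay rather than a number. That step is only a floor, and the step between compound 1 and compound 3 cannot be read, because both values are limits: the limit of > 2.41 h in this assay, at which 2 of the 3 values shown sit.

From the compounds shown here alone, how far compound 1 and compound 3 lie above that limit remains open. So does the reading with an amine on the ring, or with a longer chain in its place.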